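From Fluoro to Methyl: A Small Step Expected

This account rests on a few compounds, and the source may have more. Where it says the series, first, only, none or still open, it means among the compounds named here.

In a functional assay on T47D cells (Homo sapiens) for antiproliferative activity, read by MTT assay, with a stated time of 24 h (a lower number here means a stronger inhibitor, a higher number a weaker inhibitor), compound 1 `O=S(=O)(Nc1ccc2cc[nH]c2c1)c1ccc(F)cc1` gives 33000 nM. Compound 2 `O=C(Nc1ccc2cc[nH]c2c1)c1ccc(Br)cc1` gives 63700 nM. These two numbers lie within the usual scatter of repeated measurements, so compound 1 stands level with compound 2 and neither can be ranked.

The next compound to be tested is compound 3 `Cc1ccc(S(=O)(=O)Nc2ccc3cc[nH]c3c2)cc1`. It carries methyl in place of fluoro on an aromatic carbon, para to a large group: methyl in place of fluoro on an aromatic carbon. Going by the values given here, no measured pair shows what a change at this place does in this assay, so the data offer no direct guide. With nothing pointing either way, no shift beyond the scatter is expected, and no direction can be called. The estimated step, a 1.1-fold higher number from compound 1 to compound 3 (0.03 log units; within the scatter), is expected to stay within that scatter. Compound 3 is expected at 35000 nM, with an estimated range of 15000 nM to 80000 nM.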

Compound 3, half-maximal inhibitory concentration: 57100 nM
Estimate against measurement, compound 3: 1.6-fold (0.21 log units) below, within the range that was stated.
By their numbers in this assay, from the lowest: compounds 1, 3 and 2 (each within the scatter of the next).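

Going by these compounds alone, the first pair to differ only at this position is compound 1 and compound 3: in this assay, methyl in place of fluoro on an aromatic carbon, para to a large group, gives a 1.7-fold higher number from compound 1 to compound 3 (0.24 log units; within the scatter). The two compounds therefore stand level, and this exchange of one heavy atom for another produces no difference that can be told from repeat measurement. Nothing available bears on why these two groups give such similar results.

Going by these compounds, what an amine or a carboxylic acid at this place would do remains open, as does the effect of a longer chain there. Compound 2 differs from compound 1 in more than one place, so the separate contributions of the carbonyl link and the bromo group cannot be read from these compounds.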